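The source may report more compounds than this note shows. Statements on the series, on what has been measured and on what is new or still open speak of the compounds shown alone.

Compound 1 `Cc1ccccc1-c1nn(-c2ccc(Cl)cc2)cc1CNCCN1CCN(C)CC1` gives 17000 nM in an ADME assay on Huh-7 cells (Homo sapiens) for cytotoxicity; a higher number here means that more compound is tolerated, a lower number that less compound is tolerated.
Compound 2 `Cc1ccccc1-c1nn(-c2ccc(F)cc2)cc1CNCCN1CCN(C)CC1` gives > 20000 nM in this assay, which is a limit of the assay and not a number.
Compound 3 `Cc1ccccc1-c1nn(-c2ccc(F)cc2F)cc1CNCCN1CCN(C)CC1` gives > 20000 nM in this assay, again a limit of the assay and not a number.

Compound 3 therefore stands at the limit of > 20000 nM in this assay, at which 2 of the 3 values shown sit, so its position is known only as a limit. Only compound 1 gives a number. The measured steps among these three compounds are an at least 1.1-fold higher number from compound 1 to compound 2 (0.07 log units; that floor lies within the scatter), an at least 1.1-fold higher number from compound 1 to compound 3 (0.07 log units; that floor lies within the scatter) and a step that the two limits leave unreadable from compound 2 to compound 3; none of them reaches beyond the scatter, and all concern the aryl group on the same aromatic nitrogen.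

Compound 4 `Cc1ccccc1-c1nn(-c2ccc(C(F)(F)F)cc2)cc1CNCCN1CCN(C)CC1` differs from compound 3 by 4-(trifluoromethyl)phenyl in place of 2,4-difluorophenyl on an aromatic nitrogen. The three measured steps bear on this change, since each of them also exchanges the substitution of that aryl group, and each was small or unreadable. The expected step is accordingly an at least 1.1-fold lower number from compound 3 to compound 4 (0.04 log units; that floor lies within the scatter), with no direction beyond the scatter favoured. Compound 4 is estimated at 18000 nM, within 8000 nM to 40000 nM, in this assay.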

Compound 4, half-maximal cytotoxic concentration: 11000 nM
Compound 4: the middle estimate sits 1.6-fold (0.21 log units) above what was measured, within the range that was stated.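

Among the compounds shown here, with trifluoromethyl at this aryl group, compound 4 is the second compound here to give a number rather than a limit in this assay, and the one step between two numbers is a 1.5-fold lower number from compound 1 to compound 4 (0.19 log units; within the scatter). The other two steps start from limits of the assay and not from numbers, and they are an at least 1.8-fold lower number from compound 2 to compound 4 (0.25 log units; that floor lies within the scatter) and an at least 1.8-fold lower number from compound 3 to compound 4 (0.25 log units; that floor lies within the scatter). Their true size therefore stays unknown, and their floors do not leave the scatter, because compound 2 and compound 3 are both held at a limit: the limit of > 20000 nM in this assay, at which 2 of the 4 values shown sit.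

So the exchange of this aryl group has not yet given a change beyond the scatter in any of the four compounds shown. As far as these compounds go, whether a nitrile, a methoxy group or an amine on this phenyl ring would do so remains open, as does any effect of replacing the 2-methylphenyl group.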